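Swapping a Methylpyrazolyl Group for a Thiazolyl Group

The source may hold more compounds than are shown below. What is called first, only, known or untested is meant among the compounds shown, and "the series" means these compounds.

Compound 1 `Cn1nccc1-c1cccc2c1CCC2c1ncc[nH]1` was tested in a functional assay on CHO cells for agonist activity at Alpha-1D adrenergic receptor (Homo sapiens), read by FLIPR and calcium flux; a lower number here means that less compound is needed, a higher number that more compound is needed for the effect. In this assay compound 1 reaches only the limit of > 10000 nM, so no number is known for it. A second compound, compound 2 `c1ccc2c(c1)CCCC2c1ncc[nH]1`, which carries no aromatic group on its core, gives 364 nM in this assay. Compound 3 `c1cc(-c2nccs2)c2c(c1)C(c1ncc[nH]1)CC2` has not yet been measured. It differs from compound 1 in one place: 1,3-thiazol-2-yl in place of 1-methyl-1H-pyrazol-5-yl on an aromatic carbon. Both groups are five-membered aromatic rings with two hetero atoms, but the thiazolyl group carries no methyl. Because compound 1 sits at the limit (the limit of > 10000 nM in this assay, at which 1 of the 2 values shown sits), the expectation for compound 3 is a step toward a lower number, larger than the scatter but uncertain, and a limit may again be reported. The estimate for compound 3 is 5000 nM, with a range from 1000 nM to 30000 nM. The step expected is an at least 2.0-fold lower number from compound 1 to compound 3 (0.30 log units; that floor lies within the scatter).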

Compound 3, half-maximal effective concentration: 3190 nM
Compound 3: the middle estimate sits 1.6-fold (0.20 log units) above what was measured; the measured number falls inside the stated range.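

In this assay, this position on the aromatic carbon responds to which five-membered aromatic ring sits there: the change gives an at least 3.1-fold lower number from compound 1 to compound 3 (0.49 log units; beyond the scatter). Compound 3 gives 3190 nM, so a ring at this position can still leave a measurable number in this assay. The true size of the step stays unknown because compound 1 sits at a limit: the limit of > 10000 nM in this assay, at which 1 of the 3 values shown sits.

The 1-methyl-1H-pyrazol-5-yl and 1,3-thiazol-2-yl groups differ both in the methyl and in their ring atoms, and the compounds shown leave open which of these differences matters. They also leave open what a phenyl ring, a methoxy group or an amine would give at this same position on the shared core.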